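Vero Cell Tolerance Across Four Related Compounds

The source may report more compounds than this note shows. Statements on the series, on what has been measured and on what is new or still open speak of the compounds shown alone.

Measured so far in a toxicity assay on Vero cells (Chlorocebus sabaeus) for cytotoxicity; a higher number here means that more compound is tolerated, a lower number that less compound is tolerated:
- compound 1, `O=C(/C=C/c1ccc([N+](=O)[O-])o1)c1ccccc1`: 444000 nM
- compound 2, `COc1cc(C(=O)/C=C/c2ccc([N+](=O)[O-])o2)cc(OC)c1OC`: 384000 nM
- compound 3, `O=C(/C=C/c1ccc([N+](=O)[O-])o1)c1ccco1`: 776000 nM

Compound 1 gives the second highest of the three numbers in this assay. For the measured compounds named here, its nearest neighbour is compound 2, whose value lies within the scatter of it, and its furthest is compound 3, where the single measured step, a 1.7-fold higher number from compound 1 to compound 3 (0.24 log units; within the scatter), also stays within the scatter. Across these three compounds, then, nothing beyond the scatter has been observed.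

Compound 4, `O=C(/C=C/c1ccc([N+](=O)[O-])o1)c1ccc(N2CCCCC2)cc1`, differs from compound 1 in one place:
piperidin-1-yl in place of hydrogen on an aromatic carbon

Going by the values given here, no measured step touches this position of the core of compound 1; the one step known concerns the carbonyl carbon and was within the scatter. The account therefore has no basis for expecting a step beyond the scatter in this assay, in either direction, and treats the value of compound 1 as the anchor. Compound 4 is expected to give about 350000 nM, with a plausible range from 150000 nM to 800000 nM, which corresponds to an estimated step of a 1.3-fold lower number from compound 1 to compound 4 (0.10 log units; within the scatter).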

Compound 4, half-maximal cytotoxic concentration: 349000 nM
Estimate against measurement, compound 4: 1.0-fold (0.00 log units) above; low and high end bracket the measured number.
By their numbers in this assay, from the lowest: compounds 4, 2, 1 and 3 (each within the scatter of the next, the first and the last beyond it).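

In this assay, piperidin-1-yl in place of hydrogen on an aromatic carbon, para to a large group, gives a 1.3-fold lower number from compound 1 to compound 4 (0.10 log units; within the scatter) and so does not move the number beyond the scatter. For the compounds shown here, the one step seen earlier concerned the carbonyl carbon, whereas this one shows that the six-membered aromatic ring of carbon only can carry a group of 6 heavy atoms, itself a six-membered non-aromatic ring, with no change beyond the scatter. No evidence accompanies this result that would explain it.

The compounds shown leave open whether a smaller group at this aromatic carbon, such as a dimethylamino group, or a carboxylic acid would also stay within the scatter. They also leave open whether piperidin-1-yl would behave the same way with furan-2-yl on the carbonyl carbon, as in compound 3.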